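This account rests on a few compounds, and the source may have more. Where it says the series, first, only, none or still open, it means among the compounds named here.

Measured compounds:
Compound 1 `Fc1ccc(-c2nnc3nnc(N4CCCC4)n3n2)cc1` gives in a functional assay on BeWo cells (Homo sapiens) for cytotoxicity, read by MTT assay, with a stated time of 72 h (on this read-out lower numbers stand for stronger inhibition and higher numbers for weaker inhibition), only the limit > 100000 nM.
Compound 2 `c1ccc(-c2nnc3nnc(N4CCCC4)n3n2)cc1` gives in this assay only the limit > 100000 nM.

Among the measured compounds shown here, compound 2 therefore stands at the limit of this assay; no number is known for it, only the limit, and the one further value shown is a limit as well, (the limit of > 100000 nM in this assay, at which 2 of the 2 values shown sit). For the measured compounds named here, the single measured step, a step that the two limits leave unreadable from compound 1 to compound 2, is hydrogen in place of fluoro on an aromatic carbon; with both ends sitting at the limit, its size cannot be read.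

Compound 3 `O=[N+]([O-])c1ccc(-c2nnc3nnc(N4CCCC4)n3n2)cc1` differs from compound 2 by nitro in place of hydrogen on an aromatic carbon. Going by the values given here, no measured step involves a nitro group, and the only step in the set, a step that the two limits leave unreadable from compound 1 to compound 2, has no readable size, so the data give no direction and no size for the change in this assay; the new step is expected to remain unreadable too. Compound 3 is expected to sit at the limit of this assay once more, with an estimated value of 150000 nM in a range from 30000 nM to 1000000 nM. The step this estimate implies, a step that the limit leaves unreadable from compound 2 to compound 3, is expected to lie within the scatter.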

Compound 3, half-maximal inhibitory concentration: > 100000 nM
Compound 3: only a limit was reported; the forecaster's own chance of this, stated with the estimate: 85%; the middle value is on the limit's open side.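

In this assay compound 3 gives > 100000 nM, a limit and not a number. No step among compound 1, compound 2 and compound 3 can be read: the limit of > 100000 nM in this assay, at which 3 of the 3 values shown sit.

The compounds shown leave open what value any of the three has and how fluoro, hydrogen and nitro on the aromatic carbon rank against one another.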